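Swapping Carboxyphenyl for Anilino on the Hydrazone Nitrogen

A few compounds are considered here, and "the series" means these few. Any claim that something is new, unique, unknown or untested is made for them only; others in the source may bear on it.

Compound 3 `O=C1Nc2ccc(S(=O)(=O)N3CCOCC3)cc2/C1=N/c1ccc(C(=O)O)cc1` is one of three related compounds tested in a functional assay on HCT-116 cells (Homo sapiens) for cytotoxicity, read by sulforhodamine B assay, with a stated time of 24 h; on this read-out higher numbers stand for weaker inhibition and lower numbers for stronger inhibition. Compound 1 `N/N=C1\C(=O)Nc2ccc(S(=O)(=O)N3CCOCC3)cc21` carries a free amino group on the double-bonded nitrogen, and in this assay compound 1 gives 36300 nM. Compound 2 `N=c1oc2ccccc2cc1C(=O)N/N=C1\C(=O)Nc2ccc(S(=O)(=O)N3CCOCC3)cc21` carries a larger acyl group at that nitrogen, and in this assay compound 2 gives 6750 nM. In this assay compound 3 gives 23600 nM, the second highest of the three numbers, close to compound 1 and well apart from compound 2. For the measured compounds named here, the only single-point step among the measured compounds is a 1.5-fold lower number from compound 1 to compound 3 (0.19 log units; within the scatter). Compound 4 `O=C1Nc2ccc(S(=O)(=O)N3CCOCC3)cc2/C1=N/Nc1ccccc1` differs from compound 3 in one place: anilino in place of 4-carboxyphenyl on a double-bonded nitrogen. Going by the values given here, no measured step covers this exact change. Among the compounds with values here, the one step that touches this position, from compound 1 to compound 3, stayed within the scatter, while compound 2 shows that a group at this nitrogen can shift the number; with only that to go on, no step beyond the scatter is expected. Compound 4 is therefore estimated at 20000 nM, with a range from 7000 nM to 60000 nM. The step expected is a 1.2-fold lower number from compound 3 to compound 4 (0.07 log units; within the scatter), within the scatter.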

Compound 4, half-maximal inhibitory concentration: 10500 nM
Beside the measured number, compound 4's estimate is 1.9-fold (0.28 log units) above it; measured number inside the range.
By their numbers in this assay, from the lowest: compounds 2 and 4 (each within the scatter of the next); then compounds 3 and 1 (each within the scatter of the next).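

In this assay, for the compounds shown here, this nitrogen now shows steps beyond the scatter: anilino in place of 4-carboxyphenyl brings a 2.2-fold lower number from compound 3 to compound 4 (0.35 log units; beyond the scatter) and phenyl in place of hydrogen on the amine nitrogen brings a 3.5-fold lower number from compound 1 to compound 4 (0.54 log units; beyond the scatter), whereas the one earlier step at this position stayed within the scatter. Compound 3 and compound 4 both carry a six-membered aromatic ring of carbon only at this place, so that ring alone does not fix the number. Nothing measured here gives a reason for either step.

The swap from compound 3 to compound 4 removes a carboxylic acid and adds an amine nitrogen at once, and the compounds shown do not separate those two changes. An anilino group carrying a carboxylic acid would be one way to pull them apart, and a methyl group or a longer chain on the amine nitrogen would test whether the aromatic ring is needed at all.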